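This account rests on a few compounds, and the source may have more. Where it says the series, first, only, none or still open, it means among the compounds named here.

Measured compounds:
compound 1, `CCc1nc(NC(CC)CC)c(OC)nc1-c1ccc(OC(F)F)cc1Cl`, with 1.4 nM;
compound 2, `CCc1nc(-c2ccc(Cl)cc2Cl)c(CC)nc1NC(COC)COC`, with 224 nM.

In an assay on IMR-32 cells for displacement of a labelled ligand from corticotropin-releasing factor receptor 1 (Homo sapiens), read by scintillation counting, with a stated time of 2 h (a higher number here means a weaker inhibitor, a lower number a stronger inhibitor), compound 1 gives 1.4 nM, while compound 2 gives 224 nM. Compound 2 thus stands at the higher of the two numbers. Its gap to compound 1 lies far beyond the scatter; the two compounds differ in several places at once, so no single step accounts for it. Compound 3 `CCc1nc(-c2ccc(Cl)cc2Cl)c(CC)nc1NC(C1CC1)C1CC1` has not yet been measured. It keeps the core of compound 2 and alters only the group on a nitrogen on an aromatic ring: dicyclopropylmethyl in place of 2-methoxy-1-(methoxymethyl)ethyl on a nitrogen on an aromatic ring. Within the data shown here, no measured pair shows this change on its own. Compound 3 is expected to give a lower number than compound 2 in this assay, a step of a 22-fold lower number from compound 2 to compound 3 (1.35 log units; beyond the scatter) that is expected to reach beyond the scatter. The estimate for compound 3 is 10 nM, within a range from 2 nM to 50 nM.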

Compound 3, inhibition constant: 3.7 nM
Beside the measured number, compound 3's estimate is 2.7-fold (0.43 log units) above it, and the stated range covers the measured number.
By their numbers in this assay, from the lowest: compound 1; then compound 3; then compound 2.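

In this assay, among these compounds, the change on a nitrogen on an aromatic ring gives a 61-fold lower number from compound 2 to compound 3 (1.78 log units; beyond the scatter), the first step that can be read at a single place, and it shows that the number depends strongly on the group at this position. The two groups match in heavy-atom count, so the step comes with a change of group type at equal count: dicyclopropylmethyl brings two three-membered rings of carbon only and no hydrogen-bond acceptors, where 2-methoxy-1-(methoxymethyl)ethyl has no ring and 2 hydrogen-bond acceptors. No measurement shown here explains the size of this step.

The compounds shown do not separate the contribution of the rings from that of the lost oxygens. From the compounds shown here alone, how a hydroxyl group, an amine or a longer chain on this nitrogen would fare also remains open.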